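This account rests on a few compounds, and the source may have more. Where it says the series, first, only, none or still open, it means among the compounds named here.

Measured compounds in a functional assay on HCC 2998 cells (Homo sapiens) for inhibition, read by sulforhodamine B assay, with a stated time of 48 h; on this read-out higher numbers stand for weaker inhibition of growth and lower numbers for stronger inhibition of growth:
- compound 1 `COc1cc(-c2cc(/C=C/C(=O)c3ccc(N)cc3)[nH]n2)cc(OC)c1OC`: 3630 nM
- compound 2 `COc1ccc(-c2cc(/C=C/C(=O)c3ccc(N)cc3)[nH]n2)cc1OC`: 3830 nM

Among the measured compounds shown here, compound 1 stands alongside compound 2, the only other compound measured: the step of a 1.1-fold higher number from compound 1 to compound 2 (0.02 log units; within the scatter) separates them by no more than the scatter, so the two are indistinguishable on this read-out.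

Compound 3 `COc1cc(-c2cc(/C=C/C(=O)c3ccc(F)c(F)c3)[nH]n2)cc(OC)c1OC` has not been measured in this assay. It departs from compound 1 at the carbonyl side of the chain: 3,4-difluorophenyl in place of 4-aminophenyl on a carbonyl carbon. For the measured compounds named here, the one measured step, a 1.1-fold higher number from compound 1 to compound 2 (0.02 log units; within the scatter), concerns the hydrogen in place of methoxy on the other aromatic ring and leaves the 4-aminophenyl untouched; it therefore says nothing about what an exchange at the carbonyl carbon does. Going by the values given here, no measured compound carries anything other than 4-aminophenyl at that position, so no step bears on this change. With nothing to anchor a shift in either direction, the working expectation for compound 3 is a number close to compound 1, a 1.1-fold higher number from compound 1 to compound 3 (0.04 log units; within the scatter), with a wide range to reflect the absence of any comparable step. The estimate for compound 3 is 4000 nM, between 1000 nM and 16000 nM.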

Compound 3, concentration for total growth inhibition: 34100 nM
Compound 3: the middle estimate sits 8.5-fold (0.93 log units) below what was measured, and the stated range ends below it.
By their numbers in this assay, from the lowest: compounds 1 and 2 (each within the scatter of the next); then compound 3.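

On this evidence, the carbonyl side of the chain is a place where this assay responds to a change of group: with 3,4-difluorophenyl in place of 4-aminophenyl on a carbonyl carbon, the result is a 9.4-fold higher number from compound 1 to compound 3 (0.97 log units; beyond the scatter), towards weaker inhibition of growth. Among the compounds shown here, the only earlier step, a 1.1-fold higher number from compound 1 to compound 2 (0.02 log units; within the scatter), with hydrogen in place of methoxy on an aromatic carbon, showed no shift that could be told from scatter, so this is the first exchange to move the number beyond it. The leaving group counts 1 hydrogen-bond donor and 1 hydrogen-bond acceptor and the entering group 0 of each, but no measurement available here accounts for the shift.

The exchange removes the amine and adds both fluorines in a single step, so the compounds shown cannot separate the loss of the one from the gain of the other; plain phenyl, 4-fluorophenyl or 4-hydroxyphenyl at the same carbonyl carbon would bear on that. Also open, going by these compounds, is whether 3,4-difluorophenyl gives a similar step on the core of compound 2.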